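The source may report more compounds than this note shows. Statements on the series, on what has been measured and on what is new or still open speak of the compounds shown alone.

Measured in an ADME assay on Raji cells (Homo sapiens) for cytotoxicity, read by CellTiter-Glo and resazurin assay, with a stated time of 72 h; a higher number here means that more compound is needed for the effect, a lower number that less compound is needed:
- compound 1 `CCOC(=O)CCCCCOc1cccc(CN(C(=O)c2ccc(-c3cccc(NC(C)=O)c3)cc2)C(C)C)c1`: > 26000 nM, a limit of the assay
- compound 2 `CCOC(=O)CCCCCOc1cccc(CN(C(=O)c2ccc(-c3cnc(OC)nc3OC)cc2)C(C)C)c1`: > 26000 nM, a limit of the assay
- compound 3 `CCOC(=O)CCCCCOc1cccc(CN(C(=O)c2ccc(-c3ccc(C(C)=O)s3)cc2)C(C)C)c1`: > 26000 nM, a limit of the assay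

Compound 3 stands only at a limit in this assay: no number was reached for it. The same holds for the other two members of the series, so every step among them is unreadable: a step that the two limits leave unreadable from compound 1 to compound 2, a step that the two limits leave unreadable from compound 1 to compound 3 and a step that the two limits leave unreadable from compound 2 to compound 3 can be given neither a size nor a direction because of the limit of > 26000 nM in this assay, at which 3 of the 3 values shown sit. None of the three aryl groups on the shared core has so far produced a readable cytotoxic effect.

Compound 4 `CCOC(=O)CCCCCOc1cccc(CN(C(=O)c2ccc(-c3ccc4cc[nH]c4c3)cc2)C(C)C)c1` is the next member. Its change from compound 3 is 1H-indol-6-yl in place of 5-acetylthiophen-2-yl on an aromatic carbon. Among the measured compounds shown here, no measured step bears on this change with a readable size, since all three comparisons among compounds 1, 2 and 3 end at the same limit. With three aryl variations of the same core all sitting at the limit, the expectation is that compound 4 will also reach no number, and that a step that the limit leaves unreadable from compound 3 to compound 4 will not be readable beyond the scatter. For compound 4 the estimate in this assay is therefore 30000 nM, with a range from 10000 nM to 100000 nM, most likely reported again as a limit.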

Compound 4, half-maximal effective concentration: > 26000 nM
Compound 4 gave a limit, no number; the forecaster's own chance of this, stated with the estimate: 80%; the middle value lies beyond the limit too.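

No step between compound 4 and compound 1, compound 2 or compound 3 can be read in this assay, in size or direction, because all four compounds end at the same limit: the limit of > 26000 nM in this assay, at which 4 of the 4 values shown sit.

The compounds shown leave open whether any aryl group on the shared core gives a readable cytotoxic effect, and how these four groups would compare.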